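From diisopropylamino to pyrrolidin-1-yl on the shared core

A few compounds are considered here, and "the series" means these few. Any claim that something is new, unique, unknown or untested is made for them only; others in the source may bear on it.

In a functional assay on MCF7 cells (Homo sapiens) for antiproliferative activity, read by MTT assay, with a stated time of 48 h (a higher number here means a weaker inhibitor, a lower number a stronger inhibitor), compound 1 (`CC(C)=CCC[C@]1(C)/C=C/[C@@H](OC(=O)C=C(C)C)[C@](C)(O)/C=C/C(=O)/C(C(=O)O)=C\C1`) gives 16100 nM while compound 2 (`CC(C)=CCC[C@]1(C)/C=C/[C@@H](OC(=O)C=C(C)C)[C@](C)(O)/C=C/C(=O)/C(CN(C(C)C)C(C)C)=C\C1`) gives 780 nM and so holds the lower of the two numbers, making it the stronger inhibitor of this pair. The measured step is a 21-fold lower number from compound 1 to compound 2 (1.31 log units; beyond the scatter) and lies beyond the scatter; it comes with (diisopropylamino)methyl in place of carboxy on a double-bonded ring carbon.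

Compound 3 (`CC(C)=CCC[C@]1(C)/C=C/[C@@H](OC(=O)C=C(C)C)[C@](C)(O)/C=C/C(=O)/C(CN2CCCC2)=C\C1`) is still unmeasured and differs from compound 2 in one place (pyrrolidin-1-yl in place of diisopropylamino on a saturated chain carbon bound to a double-bonded ring carbon): pyrrolidin-1-yl in place of diisopropylamino on a saturated chain carbon bound to a double-bonded ring carbon. Going by the values given here, the one measured step bears only loosely on this change: it replaced carboxy, and no measured pair exchanges one amino group for another. Compound 3 keeps the feature that sets compound 2 apart from compound 1, so the expectation starts from compound 2 at 780 nM and not from the far higher number of compound 1. In this assay the expected change is a 1.3-fold higher number from compound 2 to compound 3 (0.11 log units; within the scatter) and stays within the scatter, with no direction that the data can settle. The estimated value for compound 3 is 1000 nM with an expected range of 350 nM to 3000 nM in this estimate.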

Compound 3, half-maximal inhibitory concentration: 220 nM
Beside the measured number, compound 3's estimate is 4.5-fold (0.66 log units) above it; the measured number lies below the stated range.
By their numbers in this assay, from the lowest: compound 3; then compound 2; then compound 1.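

In this assay, the amino group on this saturated chain carbon turns out to matter in its own right: replacing diisopropylamino with pyrrolidin-1-yl gives a 3.5-fold lower number from compound 2 to compound 3 (0.55 log units; beyond the scatter), a step beyond the usual scatter, so the choice of amine still changes the result once the carboxy group is gone. Measured against the carboxy compound, the same group gives a 73-fold lower number from compound 1 to compound 3 (1.86 log units; beyond the scatter), which shows that a second amine also sits far below the acid on the shared core and that compound 2 was not a lone case. Nothing available here explains why the group with the ring and fewer heavy atoms gives the lower number.

These three compounds cannot separate the effect of closing the amine into a ring from that of removing heavy atoms, since pyrrolidin-1-yl differs from diisopropylamino in both respects. An open-chain diethylamino group and a piperidin-1-yl ring would help to pull these two apart, while a morpholin-4-yl ring would show whether a ring oxygen is accepted at this place.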